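This account rests on a few compounds, and the source may have more. Where it says the series, first, only, none or still open, it means among the compounds named here.

Values in an ADME assay on Vero cells (Chlorocebus sabaeus) for cytotoxicity, read by MTT assay, with a stated time of 72 h; a lower number here means that less compound is needed, a higher number that more compound is needed for the effect
- compound 1 `O=C(Nc1nc(-c2ccccn2)cs1)c1cccc(Cl)c1` gives 7000 nM
- compound 2 `O=C(Nc1nc(-c2ccccn2)cs1)c1cccnc1Cl` gives 1900 nM

Of these two compounds, compound 2 has the lower number, so less of it is needed for the effect. The next compound is compound 3 `O=C(Nc1nc(-c2ccccn2)cs1)c1ccccn1` and it keeps the rest of compound 2 unchanged. It carries pyridin-2-yl in place of 2-chloropyridin-3-yl on a carbonyl carbon, and the counted difference is this: pyridin-2-yl in place of 2-chloropyridin-3-yl on a carbonyl carbon (the other neighbour of that carbon is an amide-type nitrogen).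

Among the measured compounds shown here, only one measured step bears on this change, and it concerns the same place: a 3.7-fold lower number from compound 1 to compound 2 (0.57 log units; beyond the scatter) (a modest step). It shows that a new group here can move the number in this assay but, as a single step, it cannot show the direction for a different group. For the measured compounds named here, a modest move to a higher number is expected because compound 2 at 1900 nM is the lower of only two values, so the expectation leans toward the middle of what has been seen. The estimated change is a 2.1-fold higher number from compound 2 to compound 3 (0.32 log units; beyond the scatter) (an uncertain expectation). For compound 3 the estimate is 4000 nM (expected range 1300 nM to 12000 nM).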

Compound 3, half-maximal effective concentration: 5400 nM
Beside the measured number, compound 3's estimate is 1.4-fold (0.13 log units) below it; low and high end bracket the measured number.
By their numbers in this assay, from the lowest: compound 2; then compounds 3 and 1 (each within the scatter of the next).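

In this assay, placing pyridin-2-yl on the carbonyl carbon in place of 2-chloropyridin-3-yl gives a 2.8-fold higher number from compound 2 to compound 3 (0.45 log units; beyond the scatter), so changes at this position can move the number upward as well as downward. Pyridin-2-yl and 3-chlorophenyl cannot be told apart here, with a 1.3-fold lower number from compound 1 to compound 3 (0.11 log units; within the scatter), and among these three groups only the 2-chloropyridin-3-yl of compound 2 stands clearly apart from the other two, showing that having a single ring hetero atom, as compound 3 also does, is not enough to match compound 2. Nothing measured here explains why these groups differ.

Compound 3 differs from compound 2 both in lacking the chlorine and in how its ring is attached to the carbonyl carbon, so the compounds shown leave open which of these two differences accounts for the step. On these data alone, how plain pyridin-3-yl would compare, which would separate the two differences, remains open, as does the effect of a ring carrying an amine or a carboxylic acid at this position.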